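The compounds below may be only part of what the source reports. "The series", "measured", "known", "first", "only" and "open" are said of these compounds alone.

Compound 1 `Oc1ccc(-c2cc(-c3cccc(C(F)(F)F)c3)cc(-c3ccccc3O)n2)cc1` carries a 2-hydroxyphenyl group, and in a functional assay on T47D cells (Homo sapiens) for inhibition (on this read-out lower numbers stand for stronger inhibition and higher numbers for weaker inhibition), compound 1 gives > 50000 nM, which is a limit of the assay rather than a number. Compound 2 `Oc1ccc(-c2cc(-c3cccc(C(F)(F)F)c3)cc(-c3cccc(O)c3)n2)cc1` differs from compound 1 by 3-hydroxyphenyl in place of 2-hydroxyphenyl on an aromatic carbon, and in this assay compound 2 gives 2630 nM. Going by these compounds, the step of an at least 19-fold lower number from compound 1 to compound 2 (1.27 log units; beyond the scatter) is thus large, though its true size stays open since it starts from the limit of > 50000 nM in this assay, at which 2 of the 3 values shown sit. Compound 3 `Oc1ccccc1-c1cc(-c2ccc(OC(F)(F)F)cc2)cc(-c2ccccc2O)n1` has a different core, and how that core differs from the core of compound 1 is not broken down here. In this assay compound 3 gives > 50000 nM, again a limit of the assay. Compound 4 `Oc1cccc(-c2cc(-c3ccc(OC(F)(F)F)cc3)cc(-c3ccccc3O)n2)c1` differs from compound 3 by 3-hydroxyphenyl in place of 2-hydroxyphenyl on an aromatic carbon; the surroundings are not the same as before, the group now sitting meta to a 2-hydroxyphenyl group and meta to a large group rather than meta to a 3-(trifluoromethyl)phenyl group and meta to a 4-hydroxyphenyl group, so this is the same kind of change, not the same change. On the strength of an at least 19-fold lower number from compound 1 to compound 2 (1.27 log units; beyond the scatter) one expects a step of an at least 5.0-fold lower number from compound 3 to compound 4 (0.69 log units; beyond the scatter) in the same direction, with wide uncertainty because compound 3 sits at the limit of > 50000 nM in this assay, at which 2 of the 3 values shown sit. Compound 4 is expected to give about 10000 nM, estimated between 2000 nM and 50000 nM.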

Compound 4, half-maximal inhibitory concentration: 7710 nM
Beside the measured number, compound 4's estimate is 1.3-fold (0.11 log units) above it; the range from low to high includes it.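

In this assay, putting 3-hydroxyphenyl in place of 2-hydroxyphenyl again gives a step beyond the scatter, an at least 6.4-fold lower number from compound 3 to compound 4 (0.81 log units; beyond the scatter), so the direction seen on the core of compound 1 carries over to the core of compound 3. These two cores are the only evidence shown, so this is one repeat of the change and not a rule for the whole series. It does not show that the change has the same size on both cores, since each step starts from a limit of the assay: the same change on two cores in this assay, an at least 19-fold lower number (1.27 log units; beyond the scatter) from compound 1 to compound 2 and an at least 6.4-fold lower number (0.81 log units; beyond the scatter) from compound 3 to compound 4; the limit leaves it open whether they differ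

Going by these compounds, the true size of each step therefore remains open, as does how far the effect depends on the groups around the changed ring. Also open, on these data alone, is how the number in this assay would respond if a 3-aminophenyl or 3-methoxyphenyl group stood in the same place, which would test whether the hydroxyl itself matters.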